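Swapping an Aryl Amide for a Cyclohexyl Amide

The source may report more compounds than this note shows. Statements on the series, on what has been measured and on what is new or still open speak of the compounds shown alone.

Compound 2 `COc1cc(NC(=O)CN2CCN(c3cc4c(cc3F)c(=O)c(C(=O)O)cn4C3CC3)CC2)cc(OC)c1OC` carries a 3,4,5-trimethoxyphenyl group on the amide nitrogen of the shared core. In a functional assay on A549 cells (Homo sapiens) for antiproliferative activity, read by BrdU incorporation, with a stated time of 24 h (a lower number here means a stronger inhibitor, a higher number a weaker inhibitor), compound 2 reaches only the limit of the assay, > 100000 nM, so no number is known for it. Its neighbour compound 1 `O=C(CN1CCN(c2cc3c(cc2F)c(=O)c(C(=O)O)cn3C2CC2)CC1)Nc1ccc(Cl)cc1`, with a 4-chlorophenyl group in the same place, gives 14800 nM in this assay. Within the data shown here, the one measured step, an at least 6.7-fold higher number from compound 1 to compound 2 (0.82 log units; beyond the scatter), shows a weakening on moving to the trimethoxy aryl, and its size rests on (the limit of > 100000 nM in this assay, at which 1 of the 2 values shown sits). Compound 3 `O=C(CN1CCN(c2cc3c(cc2F)c(=O)c(C(=O)O)cn3C2CC2)CC1)NC1CCCCC1` replaces the aromatic amide substituent with a saturated ring: cyclohexyl in place of 3,4,5-trimethoxyphenyl on an amide-type nitrogen. Among the measured compounds shown here, no measured step covers a saturated ring here, and compound 1 is the only compound with a real number, so the expectation for compound 3 in this assay is wide. Compound 3 is expected to give 40000 nM, between 8000 nM and 200000 nM. The expected step is an at least 2.5-fold lower number from compound 2 to compound 3 (0.39 log units; beyond the scatter).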

Compound 3, half-maximal inhibitory concentration: 20700 nM
Beside the measured number, compound 3's estimate is 1.9-fold (0.29 log units) above it; low and high end bracket the measured number.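

Replacing 4-chlorophenyl with cyclohexyl on the amide-type nitrogen gives a 1.4-fold higher number from compound 1 to compound 3 (0.15 log units; within the scatter) in this assay, so within these compounds an aromatic ring at this place is not required for a measurable number. The other new step, an at least 4.8-fold lower number from compound 2 to compound 3 (0.68 log units; beyond the scatter), also favours the saturated ring, but its size is only a lower bound that rests on a limit: the limit of > 100000 nM in this assay, at which 1 of the 3 values shown sits. Together, the two steps show that the earlier loss does not extend to every replacement of 4-chlorophenyl and is so far seen only with 3,4,5-trimethoxyphenyl.

On these data alone, how far the true value of compound 2 lies from the others remains open. So does the effect of a smaller saturated ring such as cyclopropyl, an open chain such as n-hexyl, or an amine on the ring.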